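The compounds below may be only part of what the source reports. "The series", "measured", "known", "first", "only" and "open" are said of these compounds alone.

Measured compounds:
Compound 1 `Cc1ccc(C(=O)O)cc1OCCCCOc1ccc(C(=O)CC(C)(C)C)c(O)c1C`; in an assay for positive allosteric modulation of metabotropic glutamate receptor 3 (Rattus norvegicus) (a higher number here means that more compound is needed for the effect, a lower number that less compound is needed), compound 1 gives 892 nM.
Compound 2 `Cc1c(OCCCCOc2ccc(F)c(C(=O)N(C)C)c2)ccc(C(=O)CC(C)(C)C)c1O`; in this assay compound 2 gives "not active" (no number reported).

Compound 2 stands without a number: in this assay compound 2 is reported only as "not active" (no number reported), so no half-maximal effective concentration can be set against the value of compound 1. Compound 3 `COC(=O)c1cc(OCCCCOc2ccc(C(=O)CC(C)(C)C)c(O)c2C)ccc1F` differs from compound 2 by methoxy in place of dimethylamino on a carbonyl carbon. Among the compounds with values here, no measured step covers this change, so its direction in this assay cannot be read from the data; a modest shift either way, or none beyond the scatter, is possible, and a report of no activity remains a real outcome. Compound 3 is expected to give about 4000 nM, estimated within 800 nM to 20000 nM.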

Compound 3, half-maximal effective concentration: "not active" (no number reported)
Nothing numeric was reported for compound 3; no gap can be computed for the estimate.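

Compound 2 and compound 3 are both reported only as not active in this assay, so no step can be read between them. No available evidence bears on this result. The compounds shown leave open whether dimethylcarbamoyl to methoxycarbonyl alters activity on a measurably active compound.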